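A few compounds are considered here, and "the series" means these few. Any claim that something is new, unique, unknown or untested is made for them only; others in the source may bear on it.

Among the measured compounds shown here, compound 2 `CCc1ccc(C(=O)Nc2ccc(C)c(-n3cc(-c4cccnc4)cn3)c2)cc1` gives 6520 nM in a functional assay on K562 cells (Homo sapiens) for inhibition, read by MTT assay, with a stated time of 48 h (a higher number here means a weaker inhibitor, a lower number a stronger inhibitor), the highest of the two numbers so far; compound 1 `Cc1ccc(NC(=O)c2cccc(Cl)c2)cc1-n1cc(-c2cccnc2)cn1` gives 1320 nM, and the one measured step, a 4.9-fold higher number from compound 1 to compound 2 (0.69 log units; beyond the scatter), changed the aryl on the carbonyl. Compound 3 `CCN(CC)Cc1ccc(C(=O)Nc2ccc(C)c(-n3cc(-c4cccnc4)cn3)c2)cc1` differs from compound 2 by diethylamino in place of methyl on a saturated chain carbon bound to an aromatic carbon. No measured step touches this part of the molecule, so nothing shown bears on it directly. For compound 3 the expected step is a 1.4-fold lower number from compound 2 to compound 3 (0.16 log units; within the scatter), within the scatter, with a wide range. Compound 3 is estimated at 4500 nM, between 1200 nM and 16000 nM.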

Compound 3, half-maximal inhibitory concentration: 3260 nM
Compound 3: middle estimate off by 1.4-fold (0.14 log units), on the high side; measured number inside the range.
By their numbers in this assay, from the lowest: compound 1; then compounds 3 and 2 (each within the scatter of the next).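

In this assay, among the compounds shown here, the new step, a 2.0-fold lower number from compound 2 to compound 3 (0.30 log units; within the scatter), gives the first reading at this place: diethylamino on a saturated chain carbon bound to an aromatic carbon, the ethyl of compound 2 becoming the (diethylamino)methyl of compound 3. The larger group, with its added nitrogen, leaves the two numbers within the scatter of each other, so this place tolerates it in this assay. No evidence on the origin of this result is available.

As far as these compounds go, whether a morpholine, a piperazine or a carboxylic acid on that carbon reads the same stays open. Also open, from the compounds shown here alone, is whether diethylamino gives a similar step alongside the 3-chlorophenyl of compound 1.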